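The source may hold more compounds than are shown below. What is called first, only, known or untested is meant among the compounds shown, and "the series" means these compounds.

Measured so far in a functional assay on WiDr cells (Homo sapiens) for inhibition; on this read-out higher numbers stand for weaker inhibition and lower numbers for stronger inhibition: compound 1 `CCCCNC(=O)N1CC1C#N` gives 14000 nM; compound 2 `CCOC(=O)c1ccc(NC(=O)N2CC2C#N)cc1` gives 2500 nM; compound 3 `N#CC1CN1C(=O)Nc1ccc([N+](=O)[O-])cc1` gives 4300 nM.

Among these three, compound 1 stands with the highest number, that is, the weakest inhibition. The step from compound 2 to compound 3 (a 1.7-fold higher number from compound 2 to compound 3 (0.24 log units; within the scatter)) concerns a substituent on the aromatic ring and does not touch the urea nitrogen. Compound 4 `N#CC1CN1C(N)=O` arises from compound 1 by the change (hydrogen in place of butyl on an amide-type nitrogen). Among the compounds with values here, no measured step speaks to this change, so the expectation rests on the position of compound 1 alone. Since compound 1 already gives the weakest inhibition of the set, compound 4 is expected to lie at or beyond it, with a step of a 2.9-fold higher number from compound 1 to compound 4 (0.46 log units; beyond the scatter). Compound 4 is therefore estimated at 40000 nM, with a range from 12000 nM to 130000 nM.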

Compound 4, half-maximal inhibitory concentration: > 280000 nM
Compound 4: a limit, no number; the forecaster's own chance of this, stated with the estimate: 35%; middle value at least 7.0-fold (0.84 log units) from the limit.
By their numbers in this assay, from the lowest: compounds 2 and 3 (each within the scatter of the next); then compound 1. At a limit, above all of these: compound 4.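

In this assay compound 4 gives > 280000 nM, which is a limit of the assay and not a number. Hydrogen in place of butyl on the amide-type nitrogen brings an at least 20-fold higher number from compound 1 to compound 4 (1.30 log units; beyond the scatter), so this position responds strongly, whereas the only earlier single-place change, on an aromatic carbon, stayed within the scatter. What sits on this nitrogen therefore matters greatly for inhibition in this assay.

As far as these compounds go, how far the number would climb past the limit remains open. So does how a methyl group, a longer chain or a butyl chain bearing a carboxylic acid would read at this nitrogen.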